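Exchanging the Aryl Group of Compound 1

A few compounds are considered here, and "the series" means these few. Any claim that something is new, unique, unknown or untested is made for them only; others in the source may bear on it.

Compound 1 `S=C(N/N=C/c1ccc2ccccc2n1)Nc1cccc(Br)c1` was tested in a functional assay on HL-60 cells (Homo sapiens) for antiproliferative activity, read by sulforhodamine B assay, with a stated time of 72 h (on this read-out lower numbers stand for stronger inhibition and higher numbers for weaker inhibition), and compound 1 gives 53800 nM. Of the two numbers available, this is the higher, so compound 1 is the weaker of the two. Its nearest neighbour is compound 2 `CN(C)C(=S)N/N=C/c1ccc2cccnc2n1`, which in this assay gives 560 nM; the gap between compound 1 and compound 2 lies well beyond the scatter of repeat measurements. Compound 3 `NC(=S)N/N=C/c1nc2ccccc2s1` gives in this assay only > 100000 nM; this is a limit of the assay, not a number, and it marks (the limit of > 100000 nM in this assay, at which 1 of the 3 values shown sits).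

Compound 4 `COc1ccc(NC(=S)N/N=C/c2ccc3ccccc3n2)cc1` has not been measured. It differs from compound 1 in a single place: 4-methoxyphenyl in place of 3-bromophenyl on an amide-type nitrogen. For the measured compounds named here, no pair of measured compounds shows what this exchange does, and compound 2 and compound 3 differ from compound 1 in other ways, so they offer no direct guide. The expected step is therefore small, a 1.1-fold higher number from compound 1 to compound 4 (0.05 log units; within the scatter), with no clear direction and likely within the scatter. Compound 4 is estimated at 60000 nM, in a range from 15000 nM to 200000 nM.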

Compound 4, half-maximal inhibitory concentration: 43800 nM
Beside the measured number, compound 4's estimate is 1.4-fold (0.14 log units) above it; low and high end bracket the measured number.
By their numbers in this assay, from the lowest: compound 2; then compounds 4 and 1 (each within the scatter of the next). At a limit, above all of these: compound 3.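

In this assay, the exchange on the amide-type nitrogen gives a step that stays within the scatter (a 1.2-fold lower number from compound 1 to compound 4 (0.09 log units; within the scatter)), so compound 1 and compound 4 cannot be told apart. For the compounds shown here, this is the first direct reading at this place, and it shows that 4-methoxyphenyl and 3-bromophenyl read alike here, even though the entering group brings an oxygen and a hydrogen-bond acceptor that the leaving group lacks. Nothing on hand explains this likeness.

Because the group and its place on the ring change together, this single pair cannot show what either change does alone. As far as these compounds go, it also remains open whether this nitrogen responds to anything other than a substituted phenyl, such as a longer chain, an amine or a carboxylic acid.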